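Swapping 3-cyanophenyl for 6-methoxypyridin-3-yl in compound 1

This account rests on a few compounds, and the source may have more. Where it says the series, first, only, none or still open, it means among the compounds named here.

Results in a functional assay on HeLa cells (Homo sapiens) for antiproliferative activity, read by MTT assay, with a stated time of 72 h; a higher number here means a weaker inhibitor, a lower number a stronger inhibitor:
- compound 1 `C/C=C/C(=O)Nc1cccc(Oc2nc(Nc3cccc(C#N)c3)nc3c2CSCC3)c1`: 12800 nM
- compound 2 `CCC/C=C/C(=O)Nc1cccc(Oc2nc(Nc3cccc(C#N)c3)nc3c2CSCC3)c1`: 7220 nM
- compound 3 `C/C=C/C(=O)Nc1cccc(Oc2nc(Nc3ccc(OC)nc3)nc3c2CSCC3)c1`: not yet measured

Compound 1 at 12800 nM and compound 2 at 7220 nM lie within the scatter of each other, so compound 1 has no rank apart from compound 2. Compound 3 carries 6-methoxypyridin-3-yl in place of 3-cyanophenyl on a nitrogen on an aromatic ring. Among the measured compounds shown here, the only measured step, a 1.8-fold lower number from compound 1 to compound 2 (0.25 log units; within the scatter), is a different change at a different place, ethyl in place of hydrogen on a saturated chain carbon. For the measured compounds named here, no measured step covers a change on that nitrogen, so the data give no direction. The expected change in this assay is therefore none beyond the scatter, with an estimated 1.3-fold lower number from compound 1 to compound 3 (0.11 log units; within the scatter). Compound 3 is estimated at 10000 nM, within a range of 2500 nM to 40000 nM.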

Compound 3, half-maximal inhibitory concentration: 16500 nM
Estimate against measurement, compound 3: 1.7-fold (0.22 log units) below, within the range that was stated.
By their numbers in this assay, from the lowest: compounds 2, 1 and 3 (each within the scatter of the next, the first and the last beyond it).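

In this assay, among the compounds shown here, the first measured change on this nitrogen, 6-methoxypyridin-3-yl in place of 3-cyanophenyl, gives a 1.3-fold higher number from compound 1 to compound 3 (0.11 log units; within the scatter) and so leaves the number within the scatter. At this position, then, a six-membered aromatic ring of carbon only with a nitrile gave way to a six-membered aromatic ring with one hetero atom and a methoxy group, with no measurable difference in this read-out. Nothing on hand gives a reason for this result.

The compounds shown leave open whether any group on this nitrogen would move the number beyond the scatter, for instance an unsubstituted phenyl or a ring carrying an amine or a carboxylic acid. They also leave open whether a longer chain on the amide would do so.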